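The source may report more compounds than this note shows. Statements on the series, on what has been measured and on what is new or still open speak of the compounds shown alone.

Three related compounds have been tested in a functional assay on the whole organism for inhibition, with Rattus norvegicus as the target (a lower number here means that less compound is needed, a higher number that more compound is needed for the effect), and none of them gave a number. Compound 1, with the structure `CC1CC/C(=N\Nc2ccccc2)c2ncc(C#N)c(=O)n21`, reached only a limit of the assay, > 1000 umol/kg. Compound 2, `O=C(O)c1cnc2n(c1=O)CCC/C2=N\Nc1ccccc1`, likewise stopped at a limit, > 100 umol/kg. Compound 3, `CC1CC/C(=N\Nc2ccccc2Br)c2ncc(C(=O)O)c(=O)n21`, also stayed at a limit, > 320 umol/kg. So compound 3 stands nowhere on a scale of numbers: it is known only through (the limit of > 320 umol/kg in this assay, at which 1 of the 3 values shown sits), and its two companions are known only through the limit of > 1000 umol/kg in this assay, at which 1 of the 3 values shown sits, and (the limit of > 100 umol/kg in this assay, at which 1 of the 3 values shown sits). Within the data shown here, no measured pair differs in a single place, so no step of known size exists to lean on.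

Compound 4, `CC1CC/C(=N\Nc2ccccc2O)c2ncc(C(=O)O)c(=O)n21`, differs from compound 3 in one place: hydroxy in place of bromo on an aromatic carbon. With every measured compound sitting at a limit, the expectation for the step from compound 3 to compound 4 in this assay is that it stays within the scatter, which is what a step that the limit leaves unreadable from compound 3 to compound 4 expresses. Compound 4 is therefore expected to need a dose around 500 umol/kg in this assay, with the likely range spanning 150 umol/kg to 3000 umol/kg, and most probably only a limit will be reported again.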

Compound 4, dose for 50% inhibition: > 100 umol/kg
Compound 4 was reported as a limit (the forecaster's own chance of this, stated with the estimate: 80%); the middle value is on the limit's open side.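

In this assay, among these compounds, compound 3 and compound 4 both ended at a limit, so the change from bromo to hydroxy gives no step that can be read. The compounds shown leave open what dose any of them would need for the effect, and whether this change alters that dose at all.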